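Swapping a ring on the ether side chain of compound 2

This account rests on a few compounds, and the source may have more. Where it says the series, first, only, none or still open, it means among the compounds named here.

Two compounds share one core and differ only in the group attached through an oxygen on an aromatic ring. Compound 1 `CC1(C)CCC(CN2CCN(c3ccc(C(=O)NS(=O)(=O)c4ccc(OC5CCOCC5)c([N+](=O)[O-])c4)c(Oc4cnc5[nH]ccc5c4)c3)CC2)=C(c2ccc(C(F)(F)F)cc2)C1` carries an oxan-4-yl group there, and in an assay on isolated protein for displacement of a labelled ligand from Apoptosis regulator Bcl-2 (Homo sapiens), with a stated time of 15 min (a higher number here means a weaker inhibitor, a lower number a stronger inhibitor), compound 1 gives 8.4 nM. Compound 2 `CC1(C)CCC(CN2CCN(c3ccc(C(=O)NS(=O)(=O)c4ccc(OCC5CCCOC5)c([N+](=O)[O-])c4)c(Oc4cnc5[nH]ccc5c4)c3)CC2)=C(c2ccc(C(F)(F)F)cc2)C1` carries a (oxan-3-yl)methyl group instead, and in this assay compound 2 gives 3 nM. For the measured compounds named here, that change gave a 2.8-fold lower number from compound 1 to compound 2 (0.45 log units; beyond the scatter), so compound 2 stands as the lower of the two numbers measured so far.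

Compound 3 `CN1CCC(COc2ccc(S(=O)(=O)NC(=O)c3ccc(N4CCN(CC5=C(c6ccc(C(F)(F)F)cc6)CC(C)(C)CC5)CC4)cc3Oc3cnc4[nH]ccc4c3)cc2[N+](=O)[O-])C1` is the next step. Its difference from compound 2 is 1-methylpyrrolidin-3-yl in place of oxan-3-yl on a saturated chain carbon bound to an oxygen on an aromatic ring. Going by the values given here, the single measured step concerned a different part of that side chain, the point of attachment and the added chain carbon, not the identity of the ring itself, so no measured step directly bears on this change. With only that to go on, the expected step in this assay is a 1.2-fold higher number from compound 2 to compound 3 (0.07 log units; within the scatter), that is, no change beyond the usual scatter. Compound 3 is therefore estimated at 3.5 nM, within a range from 1 nM to 12 nM.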

Compound 3, half-maximal inhibitory concentration: 0.75 nM
Beside the measured number, compound 3's estimate is 4.7-fold (0.67 log units) above it, outside the stated range (below it).
By their numbers in this assay, from the lowest: compound 3; then compound 2; then compound 1.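

In this assay, the ring itself matters at this position, not only how it is attached: 1-methylpyrrolidin-3-yl in place of oxan-3-yl, on a saturated chain carbon bound to an oxygen on an aromatic ring, gave a 4.0-fold lower number from compound 2 to compound 3 (0.60 log units; beyond the scatter) while the rest of the molecule stayed the same. The two groups have equal counts of heavy atoms and hydrogen-bond acceptors, so those counts alone do not track the change in this pair. The whole change from oxan-4-yl to (1-methylpyrrolidin-3-yl)methyl amounts to an 11-fold lower number from compound 1 to compound 3 (1.05 log units; beyond the scatter), and nothing measured here explains why the newer group gives the lower number.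

Two things changed at once in the last swap, the ring size and the hetero atom, so these compounds cannot say which one counts, or whether the methyl on the nitrogen takes part. A (1-methylpiperidin-3-yl)methyl group would keep the six-membered ring while bringing in the nitrogen, and an unsubstituted (pyrrolidin-3-yl)methyl group would test the methyl on its own.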